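The source may hold more compounds than are shown below. What is called first, only, known or untested is meant among the compounds shown, and "the series" means these compounds.

Working notes on the series. In an ADME assay on microsomes from liver (Homo sapiens) for metabolic stability, read by LC-MS, using NADPH, with stated times of 10 min and 45 min, tested at 1 uM (on this read-out lower numbers stand for slow clearance and higher numbers for fast clearance), compound 1 `COC(c1cc(Cl)c2c(c1Cl)C(=O)N(Cc1c(C)cc(C)[nH]c1=O)CC2)C1CCN(C2COC2)CC1` gives 78.3 uL/min; 72.7 uL/min (2 entries) over two entries, and compound 2 `COC(c1cc(Cl)c2c(c1Cl)C(=O)N(Cc1c(C)cc(C)[nH]c1=O)CC2)C1CCN(C(C)=O)CC1` gives 50.3 uL/min; 92.6 uL/min (2 entries) over two entries as well, the spread of which is seen in the several entries of compound 2 in this assay, 50.3 uL/min; 92.6 uL/min (2 entries). Within the data shown here, compound 3 `Cc1cc(C)c(CN2CCc3c(Cl)cc([C@@H](C)CO)c(Cl)c3C2=O)c(=O)[nH]1` is the only compound with a single entry; in this assay compound 3 gives 12.4 uL/min. Compound 4 `Cc1cc(C)c(CN2CCc3c(Cl)cc([C@H](C)CO)c(Cl)c3C2=O)c(=O)[nH]1` is the next step: the two compounds have the same atoms and bonds and differ only in configuration as drawn: 1 of 1 stereo elements differ; a stereocentre at a saturated chain carbon is drawn R in compound 3 and S in compound 4. Among the measured compounds shown here, no measured pair of this kind exists in the set, so the expectation rests on the shared atoms and bonds alone. A shift no larger than the usual scatter, in no particular direction, is expected, and the expected step is a 1.1-fold higher number from compound 3 to compound 4 (0.05 log units; within the scatter). Compound 4 is therefore estimated to give 14 uL/min, within a range of 6 uL/min to 35 uL/min.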

Compound 4, intrinsic clearance in a liver preparation (reported as CLH), per the amount of preparation that the assay uses: 15.8 uL/min
For compound 4 the middle estimate is 1.1-fold (0.05 log units) below the measured one; the range from low to high includes it.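

Among these compounds, the inversion at the saturated chain carbon gives the first readable step in this assay, a 1.3-fold higher number from compound 3 to compound 4 (0.11 log units; within the scatter). In this one pair, the configuration as drawn at this carbon therefore leaves the clearance number unchanged within the scatter. The step is also smaller than the spread between repeat entries of a single compound: the several entries of compound 2 in this assay, 50.3 uL/min; 92.6 uL/min (2 entries)

Whether the same holds for other groups on this carbon remains open, since only one pair of this kind is shown. A carboxylic acid or a longer chain in this place could give a different clearance number and a different answer on configuration.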